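A few compounds are considered here, and "the series" means these few. Any claim that something is new, unique, unknown or untested is made for them only; others in the source may bear on it.

Measured compounds:
Compound 1, `COc1ccc(C2=C(c3cc(OC)c(OC)c(OC)c3)C(=O)CC2O[SiH2]C(C)(C)C)cc1OC`: > 100 ug/mL
Compound 2, `COc1ccc(C2=C(c3cc(OC)c(OC)c(OC)c3)C(=O)C(OC(C)=O)C2)cc1Cl`: 3.5 ug/mL
Compound 3, `COc1ccc(C2=C(c3cc(OC)c(OC)c(OC)c3)C(=O)CC2C)cc1C(=O)O`: > 100 ug/mL

Going by the values given here, in an ADME assay on ECV-304 cells (Homo sapiens) for cytotoxicity, read by MTT assay, with a stated time of 72 h (a higher number here means a weaker inhibitor, a lower number a stronger inhibitor), compound 2 gives 3.5 ug/mL, the only number among the three values shown. The value of compound 1 is a limit of the assay, not a number. The value of compound 3 is likewise a limit. Among the compounds with values here, both sit at the limit of > 100 ug/mL in this assay, at which 2 of the 3 values shown sit, so compound 2 stands alone as the one compound with a measured number, and nothing else in the set is close enough in structure to give a measured step.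

Compound 4, `COc1ccc(C2=C(c3cc(OC)c(OC)c(OC)c3)C(=O)C(OC(C)=O)C2)cc1OC(C)C`, has not yet been tested in this assay. It differs from compound 2 in one place: isopropoxy in place of chloro on an aromatic carbon. The acetoxy group that compound 2 carries on its core is kept.

Within the data shown here, with no measured step between compounds that differ in one place, the direction of this change rests on expectation alone. Compound 2 gives 3.5 ug/mL in this assay, and the expected step from compound 2 to compound 4 is a 2.3-fold higher number from compound 2 to compound 4 (0.36 log units; beyond the scatter), a modest loss that may or may not pass beyond the usual scatter. For compound 4 the estimate in this assay is 8 ug/mL, with a range from 2 ug/mL to 40 ug/mL.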

Compound 4, half-maximal inhibitory concentration: > 100 ug/mL
Compound 4: no number, only a limit; the forecaster's own chance of this, stated with the estimate: 20%; middle value at least 12-fold (1.09 log units) from the limit.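

In this assay compound 4 gives > 100 ug/mL, which is a limit of the assay and not a number. Going by these compounds alone, this provides the first measured step in the set between compounds that differ in one place: putting isopropoxy in place of chloro on this aromatic carbon, ortho to a methoxy group, while the acetoxy group on the core stays, gives an at least 28-fold higher number from compound 2 to compound 4 (1.45 log units; beyond the scatter). The position is therefore not indifferent to what it carries, as this single change is enough to take the measured value of compound 2 to the limit that already held for compound 1 and compound 3: the limit of > 100 ug/mL in this assay, at which 3 of the 4 values shown sit.

Going by these compounds, because compound 4 is limited rather than measured, the true size of the step stays unknown, and one pair cannot show whether the loss follows from the departure of chloro or the arrival of isopropoxy. Also open, on these data alone, is how a methoxy, an ethoxy, a bromine or an amine on this same carbon would read against compound 2 with the acetoxy group kept, which would show where between chloro and isopropoxy the value is lost.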